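The source may hold more compounds than are shown below. What is called first, only, known or untested is meant among the compounds shown, and "the series" means these compounds.

Compound 1 `COc1ccc2cc(C3C(OC(C)=O)C(=O)N3c3cc(OC)c(OC)c(OC)c3)ccc2c1` and compound 2 `COc1ccc2cc(C3C(O)C(=O)N3c3cc(OC)c(OC)c(OC)c3)ccc2c1` share one core. In a functional assay on IMR-32 cells (Homo sapiens) for cytotoxicity (a lower number here means a stronger inhibitor, a higher number a weaker inhibitor), compound 2 gives 89 nM. For compound 1 this assay reports only a limit, > 1000 nM. The change between them is hydrogen in place of acetyl on an oxygen on a saturated carbon, and it made an at least 11-fold lower number from compound 1 to compound 2 (1.05 log units; beyond the scatter); the size of that step is known only as a lower bound because of the limit of > 1000 nM in this assay, at which 1 of the 3 values shown sits.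

Compound 3 `COc1cc(N2C(=O)C(OC(C)=O)C2c2ccc([N+](=O)[O-])o2)cc(OC)c1OC` carries a different core, and the difference between the two cores is not broken down here. In this assay compound 3 gives 811 nM. Compound 4 `COc1cc(N2C(=O)C(O)C2c2ccc([N+](=O)[O-])o2)cc(OC)c1OC` is not yet measured; it differs from compound 3 by hydrogen in place of acetyl on an oxygen on a saturated carbon, the same change at the same place as before.

A step of similar direction and size is expected here, a 12-fold lower number from compound 3 to compound 4 (1.06 log units; beyond the scatter), resting on an at least 11-fold lower number from compound 1 to compound 2 (1.05 log units; beyond the scatter). Compound 4 is accordingly estimated at 70 nM, within 15 nM to 300 nM.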

Compound 4, half-maximal inhibitory concentration: > 1000 nM
Compound 4: no number, only a limit; the forecaster's own chance of this, stated with the estimate: 5%; middle value at least 14-fold (1.15 log units) from the limit.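

In this assay, acetoxy to hydroxy gives an at least 1.2-fold higher number from compound 3 to compound 4 (0.09 log units; that floor lies within the scatter), so the drop in number seen on the core of compound 1 does not carry over to the core of compound 3, and the two steps differ: the same change on two cores in this assay, an at least 11-fold lower number (1.05 log units; beyond the scatter) from compound 1 to compound 2 and an at least 1.2-fold higher number (0.09 log units; that floor lies within the scatter) from compound 3 to compound 4, at least 13-fold (1.14 log units) apart, beyond the scatter of two such steps

Compound 4 gives > 1000 nM, which is a limit of the assay and not a number.

This shows that the change cannot be treated as a fixed step across these two cores, but with one pair per core it gives no rule for the series, and the full size of each step stays unknown because each rests on a limit: the limit of > 1000 nM in this assay, at which 2 of the 4 values shown sit.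

Still open, from the compounds shown here alone, is how a propionyl ester in place of the acetyl, or an amine in place of the hydroxy, would behave on either core.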